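The compounds below may be only part of what the source reports. "The series", "measured", "known", "first", "only" and "open" are said of these compounds alone.

Compound 1 `N#Cc1cnc(NCc2cnccc2C(F)(F)F)cc1N[C@H]1C[C@@H](O)C1` is the starting point. In an assay on isolated protein for inhibition of protein kinase C theta type (Homo sapiens), read by TR-FRET, with a stated time of 2 h (a higher number here means a weaker inhibitor, a lower number a stronger inhibitor), compound 1 gives 500 nM, the highest of the three numbers recorded so far. Compound 2 `CC1(C)[C@H](O)C[C@@H]1Nc1nc(NCc2cnccc2C(F)(F)F)ncc1C#N` gives 300 nM in this assay, and compound 3 `CC1(C)[C@@H](Nc2nc(NCc3cnccc3C(F)(F)F)ncc2C#N)C[C@@H]1O` gives 170 nM. Compounds 2 and 3 have the same atoms and bonds and differ only in how one saturated ring carbon is drawn, and their step, a 1.8-fold lower number from compound 2 to compound 3 (0.25 log units; within the scatter), is small; given (the fact that compounds 2 and 3 differ only in the configuration as drawn), a change of configuration at that carbon alone moves the number little. Compound 2 lies within the scatter of compound 1, while compound 3 lies beyond it.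

Compound 4 `CC1(C)[C@@H](Nc2cc(NCc3cnccc3C(F)(F)F)ncc2C#N)C[C@@H]1C(N)=O` has not yet been measured. Relative to compound 1 the change is 3-carbamoyl-2,2-dimethylcyclobutyl in place of 3-hydroxycyclobutyl on a nitrogen on an aromatic ring. Going by the values given here, no measured step covers this exact change: compounds 2 and 3 carry a different core, and none of the three has a carbamoyl on the ring. The expectation for compound 4 in this assay is therefore cautious, around 300 nM, with a range from 80 nM to 1200 nM, which means an estimated step of a 1.7-fold lower number from compound 1 to compound 4 (0.22 log units; within the scatter) that may not exceed the scatter.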

Compound 4, half-maximal inhibitory concentration: 1100 nM
Compound 4: the middle estimate sits 3.7-fold (0.56 log units) below what was measured; low and high end bracket the measured number.
By their numbers in this assay, from the lowest: compounds 3, 2 and 1 (each within the scatter of the next, the first and the last beyond it); then compound 4.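

On the core of compound 1, exchanging the cyclobutyl group that bears the hydroxy for the one that bears the carbamoyl and the two methyl groups gives a 2.2-fold higher number from compound 1 to compound 4 (0.34 log units; beyond the scatter) in this assay, a modest weakening. So this position still accepts the larger group with a measurable number, but this particular swap brings no gain. No measured evidence here accounts for the rise.

Going by these compounds, the swap changes two things at once, the dimethyl substitution on the ring and the carbamoyl in place of the hydroxy, so the share of each in the step stays open. Also open, on these data alone, is how the number would move with a carboxylic acid or an amine in place of the carbamoyl on the same cyclobutyl ring.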